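This account rests on a few compounds, and the source may have more. Where it says the series, first, only, none or still open, it means among the compounds named here.

Measured so far:
Compound 1 `CCCc1cc2ccccc2nc1-c1cc(-c2ccccc2)no1` — 47200 nM
Compound 2 `CCc1cc2ccccc2nc1-c1cc(-c2ccc(C)cc2)no1` — > 100000 nM

In a functional assay on MDA-MB-231 cells (Homo sapiens) for inhibition, read by MTT assay, with a stated time of 24 h (a lower number here means a stronger inhibitor, a higher number a weaker inhibitor), compound 1 gives 47200 nM. For the measured compounds named here, compound 2 reaches only the limit of this assay, > 100000 nM, so for compound 2 no number is known, only that its value lies beyond the range that was measured; this is where compound 2 stands, at the limit of > 100000 nM in this assay, at which 1 of the 2 values shown sits. Going by the values given here, the two compounds differ in more than one place, so the two values show only that compound 1 was measured and compound 2 was not.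

Compound 3 `CCCc1cc2ccccc2nc1-c1cc(-c2ccc(C)cc2)no1` has not been measured. It differs from compound 2 by methyl in place of hydrogen on a saturated chain carbon, two bonds along the chain from an aromatic carbon, which reads as ethyl to propyl. Among the compounds with values here, no measured step of this kind is available here, so the size of the step from compound 2 to compound 3 in this assay cannot be taken from a comparison; a change within the scatter, in either direction, is the plainest expectation. Compound 3 is therefore expected to give about 90000 nM, between 30000 nM and 300000 nM, which means an expected step of an at least 1.1-fold lower number from compound 2 to compound 3 (0.04 log units; that floor lies within the scatter).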

Compound 3, half-maximal inhibitory concentration: > 100000 nM
Compound 3: only a limit was reported (the forecaster's own chance of this, stated with the estimate: 50%); middle value at least 1.1-fold (0.04 log units) away from the limit.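

In this assay, methyl in place of hydrogen on an aromatic carbon gives an at least 2.1-fold higher number from compound 1 to compound 3 (0.32 log units; beyond the scatter), so this single change carries a weaker result, beyond the scatter. Going by these compounds, the size of that step is only a floor, and the true gap between the two compounds stays unknown. The change from ethyl to propyl cannot be read, because compound 2 and compound 3 both stand at a limit of this assay: the limit of > 100000 nM in this assay, at which 2 of the 3 values shown sit.

The compounds shown leave open whether a group other than methyl on that aromatic carbon, such as a methoxy group or an amine, would also give a higher number. They also leave open whether a longer chain than propyl would bring a measurable value in the absence of that methyl.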